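Replacing chloro with dimethylamino in a cytotoxicity series

A few compounds are considered here, and "the series" means these few. Any claim that something is new, unique, unknown or untested is made for them only; others in the source may bear on it.

Compound 1 `NS(=O)(=O)c1ccc(Nc2nc(NN3C(=O)/C(=C\c4ccccc4)N=C3c3ccccc3)cs2)cc1` gives 45900 nM
Compound 2 `NS(=O)(=O)c1ccc(Nc2nc(NN3C(=O)/C(=C\c4ccc(Cl)cc4)N=C3c3ccccc3)cs2)cc1` gives > 150000 nM

Both compounds were tested in a functional assay on MCF7 cells (Homo sapiens) for cytotoxicity (a lower number here means a stronger inhibitor, a higher number a weaker inhibitor), and compound 3 `CN(C)c1ccc(/C=C2/N=C(c3ccccc3)N(Nc3csc(Nc4ccc(S(N)(=O)=O)cc4)n3)C2=O)cc1` awaits the same test. Compound 2 has no number to start from: its > 150000 nM is a limit and not a measured value.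

Compound 3 differs from compound 2 by dimethylamino in place of chloro on an aromatic carbon, with dimethylamino in place of chloro on an aromatic carbon, para to a large group. For the measured compounds named here, one measured step bears on this change. Chloro in place of hydrogen on an aromatic carbon gave an at least 3.2-fold higher number from compound 1 to compound 2 (0.51 log units; beyond the scatter), which lies beyond the scatter. Going by the values given here, no measured compound carries dimethylamino, so this group's own contribution remains unknown. Since chloro came with an at least 3.2-fold higher number from compound 1 to compound 2 (0.51 log units; beyond the scatter), its removal is expected to bring compound 3 back towards compound 1 at 45900 nM, a modest step to a lower number. The expected change is an at least 2.7-fold lower number from compound 2 to compound 3 (0.43 log units; beyond the scatter), and its size is uncertain. For compound 3 the estimate is 55000 nM, with an expected range from 15000 nM to 150000 nM.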

Compound 3, half-maximal inhibitory concentration: 38900 nM
Compound 3: middle estimate off by 1.4-fold (0.15 log units), on the high side, and the stated range covers the measured number.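

Compound 3 shows that this aromatic carbon, para to a large group, can carry a substituent without the change seen with chloro in this assay. Dimethylamino in place of hydrogen gives a 1.2-fold lower number from compound 1 to compound 3 (0.07 log units; within the scatter) and so leaves the number level with that of the unsubstituted compound, while dimethylamino in place of chloro gives an at least 3.8-fold lower number from compound 2 to compound 3 (0.58 log units; beyond the scatter), which means the higher number seen with chloro is not shared by both groups placed here. The size of that second step is only a lower bound because compound 2 stands at a limit of the assay and not at a measured number: the limit of > 150000 nM in this assay, at which 1 of the 3 values shown sits.

From the compounds shown here alone, it remains open whether a smaller group such as fluoro, or a methoxy group or a carboxylic acid on this carbon, would sit level with compound 1 and compound 3 or move towards compound 2. Also open, going by these compounds, are how far compound 2 truly lies from the other two and whether any group at this place can give a number clearly lower than that of compound 1.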